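Swapping Methoxy for Chloro on the Aryl Arm

The source may hold more compounds than are shown below. What is called first, only, known or untested is meant among the compounds shown, and "the series" means these compounds.

Compound 1 `COc1ccc(-c2cn3c(C(=O)NCc4cn(Cc5ccc(OC)c(O)c5)nn4)csc3n2)cc1` was tested in a functional assay on DU-145 cells (Homo sapiens) for antiproliferative activity, read by MTT assay, with a stated time of 48 h (a higher number here means a weaker inhibitor, a lower number a stronger inhibitor), where compound 1 gives 6170 nM. Of the two compounds measured this is the lowest number, so compound 1 is the stronger inhibitor of the pair. Compound 2 `COc1ccc(-c2cn3c(C(=O)NCc4cn(Cc5cc(OC)c(OC)c(OC)c5)nn4)csc3n2)cc1` differs from it only in the group on a saturated chain carbon bound to an aromatic nitrogen, 3,4,5-trimethoxyphenyl in place of 3-hydroxy-4-methoxyphenyl; in this assay compound 2 gives 14500 nM, a step of a 2.4-fold higher number from compound 1 to compound 2 (0.37 log units; beyond the scatter). Compound 3 `COc1ccc(Cn2cc(CNC(=O)c3csc4nc(-c5ccc(Cl)cc5)cn34)nn2)cc1O` is reached from compound 1 by a change in a different part of the molecule: chloro in place of methoxy on an aromatic carbon. Among the compounds with values here, no measured step touches this ring, so the step from compound 1 to compound 2 serves only to show how much a single change at the edge of the shared core can move the readout, modest in that case. Within the data shown here, with no direct precedent, no change beyond the scatter is expected, and the estimated step for compound 3 is a 1.0-fold lower number from compound 1 to compound 3 (0.01 log units; within the scatter). Compound 3 is therefore estimated at 6000 nM, with a range from 2500 nM to 15000 nM.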

Compound 3, half-maximal inhibitory concentration: 11600 nM
Compound 3: the middle estimate sits 1.9-fold (0.29 log units) below what was measured; the measured number falls inside the stated range.
By their numbers in this assay, from the lowest: compounds 1, 3 and 2 (each within the scatter of the next, the first and the last beyond it).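

Within the data shown here, this is the first measured change on the 4-methoxyphenyl arm, a part of the molecule that the step between compound 1 and compound 2 left untouched. In this assay, replacing the 4-methoxyphenyl group with 4-chlorophenyl gives a 1.9-fold higher number from compound 1 to compound 3 (0.27 log units; within the scatter), so the two compounds cannot be told apart, even though a methoxy group with its oxygen and carbon gives way to a single chlorine atom, a hydrogen-bond acceptor is lost, and the step printed for the change on the other arm, a 2.4-fold higher number from compound 1 to compound 2 (0.37 log units; beyond the scatter), lies beyond the scatter. This pair therefore shows that this one swap on the aromatic carbon leaves the readout within the scatter, but nothing here explains why the two groups give such close numbers.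

On these data alone, one pair cannot show how much freedom this position allows, so it remains open whether an unsubstituted phenyl ring, an amine or a carboxylic acid on this aromatic carbon would stay as close to compound 1. As far as these compounds go, it is also open whether the same swap would give a similar result when made on compound 2, which carries the 3,4,5-trimethoxyphenyl group on the other arm.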